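The source may report more compounds than this note shows. Statements on the series, on what has been measured and on what is new or still open speak of the compounds shown alone.

In a functional assay on HT-29 cells (Homo sapiens) for antiproliferative activity, read by sulforhodamine B assay, with a stated time of 48 h (on this read-out higher numbers stand for weaker inhibition and lower numbers for stronger inhibition), two compounds built on one shared core have been measured. Compound 1 `CCc1ccc(NS(=O)(=O)c2ccc(N3CCNC3=O)cc2)cc1` gives 660 nM, and compound 2 `Cc1ccccc1NS(=O)(=O)c1ccc(N2CCNC2=O)cc1` gives 200 nM. Among the measured compounds shown here, the single step between them, a 3.3-fold lower number from compound 1 to compound 2 (0.52 log units; beyond the scatter), exchanges one substituted phenyl group on the sulfonamide nitrogen for another. For the measured compounds named here, on these two numbers compound 2 stands lowest, and its only neighbour is compound 1, separated from it by that one step.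

Compound 3 `COc1ccccc1NS(=O)(=O)c1ccc(N2CCNC2=O)cc1` has not yet been measured. It differs from compound 2 in one place: methoxy in place of methyl on an aromatic carbon. Going by the values given here, the only measured step, a 3.3-fold lower number from compound 1 to compound 2 (0.52 log units; beyond the scatter), moved a group between different positions of the phenyl ring and replaced ethyl with methyl; it says nothing about a methoxy group, and no other measured compound carries one. A change of this kind, a small group swapped for another small group at the same position, is expected to shift the number little, probably not beyond the scatter, with the step of a 1.3-fold higher number from compound 2 to compound 3 (0.11 log units; within the scatter) as the expectation. Compound 3 is therefore estimated at 260 nM, in a range from 100 nM to 700 nM.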

Compound 3, half-maximal inhibitory concentration: 550 nM
For compound 3 the middle estimate is 2.1-fold (0.33 log units) below the measured one, within the range that was stated.
By their numbers in this assay, from the lowest: compound 2; then compounds 3 and 1 (each within the scatter of the next).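

In this assay, the change from 2-methylphenyl to 2-methoxyphenyl, on an aromatic carbon ortho to a large group, exchanges one small group for another, and it still moves the number beyond the scatter (a 2.8-fold higher number from compound 2 to compound 3 (0.44 log units; beyond the scatter)), so this position is not indifferent to which group sits on it. The same result also links two different substitutions: compound 1 and compound 3 sit within the scatter of each other (a 1.2-fold lower number from compound 1 to compound 3 (0.08 log units; within the scatter)), so among these three compounds only the 2-methylphenyl group of compound 2 stands apart, and 4-ethylphenyl and 2-methoxyphenyl cannot be told apart. Nothing shown here offers an explanation for this difference between methyl and methoxy.

The compounds shown leave open how other groups on this same carbon, such as a chlorine atom, a hydroxyl or an amine, would compare with methyl and methoxy. Among the compounds shown here, they also hold no pair in which one group stays the same and only its place on the phenyl ring changes, so the effect of place cannot yet be separated from the effect of the group itself.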